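The source may report more compounds than this note shows. Statements on the series, on what has been measured and on what is new or still open speak of the compounds shown alone.

Measured in a functional assay on BV-2 cells (Mus musculus) for inhibition, read by Griess assay, with a stated time of 24 h; on this read-out lower numbers stand for stronger inhibition and higher numbers for weaker inhibition:
compound 1 `C=CCn1ccc(-c2cc(Br)ccc2O)n1`: 112000 nM
compound 2 `C=CCn1ccc(-c2cc(Br)ccc2OC)n1`: > 200000 nM

Not yet measured: compound 3 `COc1ccc(Br)cc1-c1ccn(Cc2ccccc2)n1`

Compound 2 gives no number on this scale, only a limit of the assay: > 200000 nM.

Compound 3 keeps the core of compound 2 but carries benzyl where compound 2 carries allyl, which means phenyl in place of vinyl on a saturated chain carbon bound to an aromatic nitrogen. Going by the values given here, the one measured step, an at least 1.7-fold higher number from compound 1 to compound 2 (0.25 log units; that floor lies within the scatter), is a different change: methyl in place of hydrogen on an oxygen on an aromatic ring. Among the compounds with values here, its floor lies within the scatter, and no measured step touches the chain on the aromatic nitrogen. In this assay, therefore, no step beyond the scatter is expected in either direction. The expected step is a number no higher from compound 2 to compound 3 (the limit leaves the size open). Compound 3 is estimated at 200000 nM, with an expected range from 70000 nM to 400000 nM.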

Compound 3, half-maximal inhibitory concentration: > 200000 nM
Compound 3 gave a limit, no number; the forecaster's own chance of this, stated with the estimate: 55%; the middle value lies on the limit itself.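

No step can be read from compound 2 to compound 3, because both stop at the same limit of the assay, which gives no number to compare: the limit of > 200000 nM in this assay, at which 2 of the 3 values shown sit.

In this assay the compounds shown leave open whether benzyl in place of allyl changes inhibition at all.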